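The source may hold more compounds than are shown below. What is called first, only, known or untested is meant among the compounds shown, and "the series" means these compounds.

Going by the values given here, compound 2 `O=C(OCC1CCCN(CCCc2ccccc2)C1)c1ccccc1C(F)(F)F` holds the lowest of the two numbers so far: in a functional assay with Neuronal acetylcholine receptor; alpha3/beta4 (Homo sapiens) as the target (on this read-out higher numbers stand for weaker inhibition and lower numbers for stronger inhibition), compound 2 gives 3200 nM, and its only neighbour, compound 1 `CC1C(=O)N(c2ccccc2C(=O)OCC2CCCN(CCCc3ccccc3)C2)C(=O)C1C`, gives 6000 nM in this assay, a gap within the scatter. Compound 3 `O=C(OCC1CCCN(CCCc2ccccc2)C1)c1ccccc1N1C(=O)c2ccccc2C1=O` differs from compound 2 by a group of 11 heavy atoms (8 carbon, 1 nitrogen, 2 oxygen; one five-membered non-aromatic ring with 1 hetero atom, one six-membered aromatic ring of carbon only) in place of a group of 4 heavy atoms (1 carbon, 3 fluorine; no ring), on an aromatic carbon. Among the compounds with values here, the one measured step that bears on this change, a 1.9-fold lower number from compound 1 to compound 2 (0.27 log units; within the scatter), exchanged a larger group for the trifluoromethyl without moving the number beyond the scatter, and the reverse direction of that step is the nearest guide here. Returning a larger group to the same carbon is therefore expected to change little, a 1.6-fold higher number from compound 2 to compound 3 (0.19 log units; within the scatter). Compound 3 is estimated at 5000 nM in this assay, with a range of 1500 nM to 16000 nM.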

Compound 3, half-maximal inhibitory concentration: 1300 nM
Beside the measured number, compound 3's estimate is 3.8-fold (0.59 log units) above it; measured number outside the range, below it.
By their numbers in this assay, from the lowest: compound 3; then compounds 2 and 1 (each within the scatter of the next).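

Going by these compounds alone, at this aromatic carbon, ortho to a large group, the first steps beyond the scatter appear in this assay: a 2.5-fold lower number from compound 2 to compound 3 (0.39 log units; beyond the scatter) and a 4.6-fold lower number from compound 1 to compound 3 (0.66 log units; beyond the scatter). The six-membered aromatic ring of carbon only thus accompanies a lower number, whereas the earlier exchange of groups stayed within the scatter. No measurement here accounts for this step. On these data alone, whether the six-membered aromatic ring itself carries the step remains open, as the shared core is held constant throughout. An amine, a carboxylic acid or a methoxy group on this carbon could test how far the position extends.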